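Methoxy Added to a Ketone and an Oxime Pair

The source may report more compounds than this note shows. Statements on the series, on what has been measured and on what is new or still open speak of the compounds shown alone.

Compound 1, `Cn1c(=O)c2[nH]c(SCC(=O)c3ccccc3)nc2n(C)c1=O`, and compound 2, `COc1ccc(C(=O)CSc2nc3c([nH]2)c(=O)n(C)c(=O)n3C)cc1`, are related by methoxy in place of hydrogen on an aromatic carbon. In a functional assay on MCF7 cells (Homo sapiens) for inhibition, read by MTT assay, with a stated time of 48 h (on this read-out higher numbers stand for weaker inhibition and lower numbers for stronger inhibition), compound 1 gives 5100 nM. In this assay compound 2 gives 7600 nM. That change made a 1.5-fold higher number from compound 1 to compound 2 (0.17 log units; within the scatter). Compound 3, `Cn1c(=O)c2[nH]c(SC/C(=N/O)c3ccccc3)nc2n(C)c1=O`, carries a different core; how the two cores differ is not broken down here. In this assay compound 3 gives 5900 nM, a number that sits close to the other two. Compound 4, `COc1ccc(/C(CSc2nc3c([nH]2)c(=O)n(C)c(=O)n3C)=N\O)cc1`, differs from compound 3 by methoxy in place of hydrogen on an aromatic carbon, the same change made at the same place as the one already measured. Because of a 1.5-fold higher number from compound 1 to compound 2 (0.17 log units; within the scatter), compound 4 is expected to show a similarly small step, a 1.4-fold higher number from compound 3 to compound 4 (0.16 log units; within the scatter). The estimate for compound 4 is therefore 8500 nM, with a range expected from 5000 nM to 15000 nM.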

Compound 4, half-maximal inhibitory concentration: 800 nM
For compound 4 the middle estimate is 11-fold (1.03 log units) above the measured one, outside the stated range (below it).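

In this assay, going from phenyl to 4-methoxyphenyl on the oxime core gave a 7.4-fold lower number from compound 3 to compound 4 (0.87 log units; beyond the scatter), so the small step seen on the ketone core did not carry over. The two steps clearly differ: the same change on two cores in this assay, a 1.5-fold higher number (0.17 log units; within the scatter) from compound 1 to compound 2 and a 7.4-fold lower number (0.87 log units; beyond the scatter) from compound 3 to compound 4, 11-fold (1.04 log units) apart, beyond the scatter of two such steps. A step measured on one core therefore cannot be assumed to hold on another in this series, but one pair per core does not show why the steps differ or what the change would do on a further core.

The compounds shown leave open whether the oxime core would respond in the same way to a different group at that place, such as an amine or a carboxylic acid. They also leave open whether a longer chain, such as ethoxy, would behave like methoxy.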